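Chalcone-type ketones with a substituted allylic arm

The source may hold more compounds than are shown below. What is called first, only, known or untested is meant among the compounds shown, and "the series" means these compounds.

Measured to date:
compound 1, `O=C(/C(=C/C1CCCCC1)CCl)c1ccccc1`, 30000 nM in a functional assay on HeLa cells (Homo sapiens) for inhibition, read by sulforhodamine B assay, with a stated time of 48 h; a higher number here means a weaker inhibitor of growth, a lower number a stronger inhibitor of growth
compound 2, `O=C(/C(=C/c1ccc(Cl)cc1Cl)CCl)c1ccccc1`, 15000 nM
compound 3, `CC(=O)OC/C(=C\C1CCCCC1)C(=O)c1ccccc1`, 21000 nM

Compound 3 stands second highest of the three numbers in this assay. Its nearest neighbour is compound 2, whose number is lower, and its furthest is compound 1, whose number is higher; both gaps are stated to fall within the scatter, so no order among the three can be claimed.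

The next compound, compound 4, `CC(=O)OC/C(=C\c1ccccc1)C(=O)c1ccccc1`, differs from compound 3 by phenyl in place of cyclohexyl on a double-bonded chain carbon bound to a double-bonded chain carbon. Within the data shown here, no measured step covers exactly this change. Among the measured compounds shown here, the one measured step, a 1.4-fold lower number from compound 1 to compound 3 (0.15 log units; within the scatter), concerns the other arm and is within the scatter, so it says nothing about the ring swap. Compound 1 and compound 2 differ at the same place as the present change, cyclohexyl against a chlorinated phenyl, and their two values sit within the scatter of each other; that comparison is only a loose guide.

The expectation for compound 4 is therefore a step of a 1.4-fold lower number from compound 3 to compound 4 (0.15 log units; within the scatter), not clearly beyond the scatter. Compound 4 is estimated at 15000 nM, with a range from 6000 nM to 40000 nM.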

Compound 4, concentration for 50% growth inhibition: 20000 nM
For compound 4 the middle estimate is 1.3-fold (0.12 log units) below the measured one, within the range that was stated.
By their numbers in this assay, from the lowest: compounds 2, 4, 3 and 1 (each within the scatter of the next).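

In this assay, among these compounds, the change to phenyl in place of cyclohexyl on a double-bonded chain carbon bound to a double-bonded chain carbon, with the acetoxy arm held constant, gives a 1.1-fold lower number from compound 3 to compound 4 (0.02 log units; within the scatter), the first direct reading of this ring change. Among the compounds shown here, at this position and with this arm, the aromatic and non-aromatic six-membered rings of carbon only are therefore not told apart in this read-out, so ring aromaticity alone gives no measurable step here, and both steps now available, one at each place, stay within the scatter. Nothing at hand bears on why the two rings read alike.

For the compounds shown here, still open is whether the ring change reads the same with chloro in place of acetoxy on the saturated chain carbon bound to a double-bonded chain carbon, since the steps so far cover the ring change with the acetoxy arm only. Also open, going by these compounds, is whether an amine or a carboxylic acid on the phenyl ring, or a longer chain in place of acetoxy, would give a step beyond the scatter.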